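The source may report more compounds than this note shows. Statements on the series, on what has been measured and on what is new or still open speak of the compounds shown alone.

Compound 1 `CC(C)c1cccc(C(C)C)c1OC(=O)NS(=O)(=O)N1CCCC1`: 53000 nM in an assay on liver for inhibition of sterol O-acyltransferase 1 (Rattus norvegicus), using microsomes; on this read-out higher numbers stand for weaker inhibition and lower numbers for stronger inhibition
Compound 2 `CC(C)c1cccc(C(C)C)c1OC(=O)NS(=O)(=O)N(C(C)C)C1CCCCC1`: 5100 nM
Compound 3 `Cc1cc(C(C)(C)C)c(OC(=O)NS(=O)(=O)N(C(C)C)C(C)C)c(C(C)(C)C)c1`: 3200 nM

Compound 3 has the lowest of the three numbers shown, but its nearest neighbour, compound 2, lies within the scatter, so the two cannot be told apart; only compound 1 stands clearly apart, with a much higher number. Compound 4 `CCCCCCNS(=O)(=O)NC(=O)Oc1c(C(C)(C)C)cc(C)cc1C(C)(C)C` has not yet been measured. It differs from compound 3 in one place: hexylamino in place of diisopropylamino on a sulfonyl sulfur. Among the measured compounds shown here, no measured pair shows this kind of change, so the size of the step cannot be read off from the data. The expected step is a 1.6-fold higher number from compound 3 to compound 4 (0.19 log units; within the scatter), a small move toward a higher number, not clearly beyond the scatter. The estimate for compound 4 is 5000 nM, with a range from 1500 nM to 20000 nM.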

Compound 4, half-maximal inhibitory concentration: 19400 nM
For compound 4 the middle estimate is 3.9-fold (0.59 log units) below the measured one; low and high end bracket the measured number.
By their numbers in this assay, from the lowest: compounds 3 and 2 (each within the scatter of the next); then compound 4; then compound 1.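

Among the compounds shown here, replacing diisopropylamino with hexylamino on a sulfonyl sulfur gives a 6.1-fold higher number from compound 3 to compound 4 (0.78 log units; beyond the scatter) in this assay and is the only readable step here, so this position is sensitive to how the same atoms are joined. The hexylamino group carries a hydrogen-bond donor that diisopropylamino lacks, yet nothing shown separates that difference from the change in chain shape, and no evidence bears on the cause. Going by these compounds, whether butylamino or isopropylamino would behave like hexylamino remains open. So does whether the same change would carry over to the core of compound 1.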